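Removing one methoxy from the aryl ring of a triazole thioacetamide

The source may report more compounds than this note shows. Statements on the series, on what has been measured and on what is new or still open speak of the compounds shown alone.

Measured so far:
compound 1 `CCn1c(SCC(=O)Nc2ccc(C(C)=O)cc2)nnc1-c1ccc(OC)c(OC)c1` — 59%
compound 2 `CCn1c(SCC(=O)Nc2ccc(C(C)=O)cc2)nnc1-c1cc(OC)c(OC)c(OC)c1` — 50%
compound 3 `C=CCn1c(SCC(=O)Nc2ccc(/C(C)=N/O)cc2)nnc1-c1ccc(OC)c(OC)c1` — 56%

Of the compounds shown here, three have been measured in a functional assay on the whole organism (strain albino) for inhibition, with Rattus norvegicus as the target, read by paw edema, with stated times of 30 min and 2 h, at a dose of 0.28 mmol/kg by the oral route; on this read-out higher numbers stand for more inhibition at the one dose given (going by the name of the read-out) and lower numbers for less inhibition. Compound 1 `CCn1c(SCC(=O)Nc2ccc(C(C)=O)cc2)nnc1-c1ccc(OC)c(OC)c1` gives 59%, compound 2 `CCn1c(SCC(=O)Nc2ccc(C(C)=O)cc2)nnc1-c1cc(OC)c(OC)c(OC)c1` gives 50%, and compound 3 `C=CCn1c(SCC(=O)Nc2ccc(/C(C)=N/O)cc2)nnc1-c1ccc(OC)c(OC)c1` gives 56%. Compounds 1 and 2 differ in one place, (hydrogen in place of methoxy on an aromatic carbon), and the step of a number 9 percentage points higher from compound 2 to compound 1 (within the scatter). The difference between the cores of compound 3 and compound 2 is not broken down here; their two values lie within the scatter of each other.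

Compound 4 `C=CCn1c(SCC(=O)Nc2ccc(/C(C)=N/O)cc2)nnc1-c1ccc(OC)cc1` has not yet been measured. It differs from compound 3 by hydrogen in place of methoxy on an aromatic carbon. This is the same kind of change as that from compound 2 to compound 1, though the surroundings are not identical: in the earlier pair the place was also meta to a methoxy group, which is not so here. Since the measured step of this kind, a number 9 percentage points higher from compound 2 to compound 1 (within the scatter), stayed within the scatter, the step from compound 3 to compound 4 is expected to be of similar size, a number 2 percentage points higher from compound 3 to compound 4 (within the scatter). In this assay compound 4 is therefore estimated at 58%, with a range from 45% to 70%.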

Compound 4, a percentage reported as inhibition, in the whole organism at one dose (the size of the read-out at that dose, not a potency): 59%
The estimate for compound 4 lay 1 percentage points below the measured number; low and high end bracket the measured number.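

In this assay, replacing a methoxy with hydrogen, which turns 3,4-dimethoxyphenyl into 4-methoxyphenyl, gives a number 3 percentage points higher from compound 3 to compound 4 (within the scatter). Set beside the earlier case, the change carries from one core to the other with no difference that can be told apart: the same change on two cores in this assay, a number 9 percentage points higher (within the scatter) from compound 2 to compound 1 and a number 3 percentage points higher (within the scatter) from compound 3 to compound 4, 6 percentage points apart, within the scatter of two such steps This shows only that the change leaves the read-out within the scatter on both cores at this one dose; it does not show that losing a methoxy raises inhibition on either core, nor that the two steps are truly equal, and two pairs are a narrow basis for any rule in the series.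

The compounds shown leave open what an aryl ring with no methoxy at all would give, and whether a halogen, a hydroxyl or an amine could stand in place of the methoxy. Also open, on these data alone, is how a longer chain in place of the ethyl or allyl group, or a carboxylic acid in place of the acetyl or oxime group, would read.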